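A Further Chloro on Compound 2

The compounds below may be only part of what the source reports. "The series", "measured", "known", "first", "only" and "open" are said of these compounds alone.

In an ADME assay on L6 cells (Rattus norvegicus) for cytotoxicity, read by fluorescence and resazurin assay, with a stated time of 72 h (a lower number here means that less compound is tolerated, a higher number that more compound is tolerated), compound 1 (`N#Cc1ccc(C(c2ccn(-c3ccc(Cl)cc3)c2)n2ccnc2)cc1`) gives 42400 nM and compound 2 (`Clc1ccc(-n2ccc(C(c3ccc(Cl)cc3Cl)n3ccnc3)c2)cc1`) gives 13900 nM. Among the compounds with values here, compound 2 therefore holds the lower of the two numbers so far. Compound 3 (`Clc1ccc(C(c2ccn(-c3ccc(Cl)cc3Cl)c2)n2ccnc2)c(Cl)c1`) has not yet been measured. It differs from compound 2 by chloro in place of hydrogen on an aromatic carbon, ortho to a large group and meta to a chloro group, which turns 4-chlorophenyl into 2,4-dichlorophenyl: chloro in place of hydrogen on an aromatic carbon.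

Within the data shown here, no measured step covers this exact change. The nearest guide is a 3.1-fold lower number from compound 1 to compound 2 (0.48 log units; beyond the scatter), a modest step that brought in 2,4-dichlorophenyl in place of 4-cyanophenyl on a saturated chain carbon bound to an aromatic carbon and an aromatic nitrogen. With that single step as the guide, a small move towards a lower number in this assay is expected, one that may not clear the scatter. The expected step is a 1.7-fold lower number from compound 2 to compound 3 (0.24 log units; within the scatter). Compound 3 is estimated at 8000 nM, with an expected range of 3500 nM to 18000 nM.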

Compound 3, half-maximal cytotoxic concentration: 9260 nM
Compound 3: the middle estimate sits 1.2-fold (0.06 log units) below what was measured; low and high end bracket the measured number.
By their numbers in this assay, from the lowest: compounds 3 and 2 (each within the scatter of the next); then compound 1.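

In this assay, chloro in place of hydrogen on an aromatic carbon, ortho to a large group and meta to a chloro group, gives a 1.5-fold lower number from compound 2 to compound 3 (0.18 log units; within the scatter), so turning 4-chlorophenyl into 2,4-dichlorophenyl at this position does not shift the number beyond the scatter. Within the data shown here, the only earlier step, a 3.1-fold lower number from compound 1 to compound 2 (0.48 log units; beyond the scatter), lay at a different place, on the aryl group carried by the saturated chain carbon, and it did clear the scatter; the new result adds the first reading for a change on the other aryl group, and that reading is a step too small to separate the two compounds. Nothing measured in the material shown speaks to what lies behind the size of this step.

Only chloro has been read at this position, so the compounds shown leave open whether a methyl group, a methoxy group or an amine on the same aromatic carbon would give a number clearly apart from that of compound 2. They also leave open whether a larger change to this aryl group, such as a nitrile in place of its 4-chloro group, would move the number beyond the scatter.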